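Swapping the nitrogen group among compounds stuck at a limit

The source may hold more compounds than are shown below. What is called first, only, known or untested is meant among the compounds shown, and "the series" means these compounds.

Compound 1 `COc1ccc([C@H]2CC(=O)N(Cc3cccc(N)c3)C2)cc1OC1CCCC1` gives > 10000 nM as a limit
Compound 2 `COc1ccc([C@H]2CC(=O)N(c3cccc(O)c3)C2)cc1OC1CCCC1` gives > 10000 nM as a limit
Compound 3 `COc1ccc([C@H]2CC(=O)N(c3ccccc3N)C2)cc1OC1CCCC1` gives > 10000 nM as a limit

In a functional assay on HEK293 cells (Homo sapiens) for cytotoxicity (on this read-out lower numbers stand for higher toxicity in this test and higher numbers for lower toxicity in this test), compound 3 stands at > 10000 nM and this is a limit, not a number. It has no place of its own in a ranking, for what the three compounds share is the limit of > 10000 nM in this assay, at which 3 of the 3 values shown sit, and nothing finer.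

The next compound is compound 4 `COc1ccc([C@H]2CC(=O)N(c3ccc(C#N)cc3)C2)cc1OC1CCCC1` on the same core. It carries 4-cyanophenyl in place of 2-aminophenyl on an amide-type nitrogen in a ring, a change counted as 4-cyanophenyl in place of 2-aminophenyl on an amide-type nitrogen in a ring in full.

Three measured changes at this same nitrogen bear on it. They are a step that the two limits leave unreadable from compound 1 to compound 2 and a step that the two limits leave unreadable from compound 1 to compound 3 and a step that the two limits leave unreadable from compound 2 to compound 3 and none of them has a size that can be read. They therefore offer no size or direction to carry over, although each swap left the result at the limit. On that basis, no step beyond the usual scatter is expected in this assay for this change.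

The estimate is a step that the limit leaves unreadable from compound 3 to compound 4 and it should be read as an expectation only.

The expected value for compound 4 is 15000 nM with an estimated range of 8000 nM to 40000 nM and a report of only a limit is the likeliest outcome.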

Compound 4, half-maximal cytotoxic concentration: > 10000 nM
Compound 4: only a limit was reported; the forecaster's own chance of this, stated with the estimate: 85%; the middle value does not contradict the limit.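

In this assay compound 4 gives > 10000 nM as a limit, not a number. No step among compound 1, compound 2, compound 3 and compound 4 can therefore be read, and all four share one result: the limit of > 10000 nM in this assay, at which 4 of the 4 values shown sit.

The compounds shown leave open how much these four groups on the nitrogen differ, and whether any group there gives a value that is a number.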